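From compound 3 to compound 4: one group exchanged

The compounds below may be only part of what the source reports. "The series", "measured", "known", "first", "only" and "open" are said of these compounds alone.

- compound 1 `COc1cc(C=C(C(=O)/C=C/c2cccc(OC)c2OC)C(=O)/C=C/c2cccc(OC)c2OC)ccc1O`: 480 nM
- compound 2 `COc1ccc(C=C(C(=O)/C=C/c2cccc(OC)c2OC)C(=O)/C=C/c2cccc(OC)c2OC)cc1OC`: 560 nM
- compound 3 `COc1cccc(C=C(C(=O)/C=C/c2cccc(OC)c2OC)C(=O)/C=C/c2cccc(OC)c2OC)c1OC`: 520 nM

In a functional assay on MCF7 cells (Homo sapiens) for antiproliferative activity, read by sulforhodamine B assay, with a stated time of 48 h (on this read-out higher numbers stand for weaker inhibition and lower numbers for stronger inhibition), compound 3 stands level with the other two compounds, within the scatter of both. Compound 4 `COc1cccc(/C=C/C(=O)C(=Cc2ccc(O)c(F)c2)C(=O)/C=C/c2cccc(OC)c2OC)c1OC` carries 3-fluoro-4-hydroxyphenyl in place of 2,3-dimethoxyphenyl on a double-bonded chain carbon bound to a double-bonded chain carbon. Two measured steps exchange the group at this place, a 1.1-fold higher number from compound 1 to compound 3 (0.03 log units; within the scatter) and a 1.1-fold lower number from compound 2 to compound 3 (0.03 log units; within the scatter), and both are small. Going by the values given here, no measured compound carries fluorine, so that part of the change is untested. No change beyond the scatter is therefore expected in this assay, in either direction. The estimated result is a 1.0-fold lower number from compound 3 to compound 4 (0.02 log units; within the scatter). For compound 4 the expected value is 500 nM, with an estimated range of 250 nM to 1000 nM.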

Compound 4, half-maximal inhibitory concentration: 300 nM
Compound 4: middle estimate off by 1.7-fold (0.22 log units), on the high side; measured number inside the range.
By their numbers in this assay, from the lowest: compounds 4, 1, 3 and 2 (each within the scatter of the next).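

Compound 4 brings the first fluorine to this place, and in this assay the 3-fluoro-4-hydroxyphenyl group still stands level with all three earlier groups (a 1.7-fold lower number from compound 3 to compound 4 (0.24 log units; within the scatter)) (a 1.9-fold lower number from compound 2 to compound 4 (0.27 log units; within the scatter)). The closest comparison, fluoro in place of methoxy on an aromatic carbon, also stays inside the scatter (a 1.6-fold lower number from compound 1 to compound 4 (0.20 log units; within the scatter)). Nothing available accounts for the values at this place.
On these data alone, whether an amine or a carboxylic acid on this ring would keep the number level remains open. As far as these compounds go, all four compounds share the rest of the structure, so changes elsewhere also remain open.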